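Nitro for bromo on the benzamide of compound 2

The compounds below may be only part of what the source reports. "The series", "measured", "known", "first", "only" and "open" are said of these compounds alone.

Compound 2 `O=C(Nc1cccc(-c2oc3cc(-c4ccc(F)cc4)ccc3c(=O)c2O)c1)c1ccc(Br)cc1` carries a bromo substituent on the benzamide ring and gives 25400 nM in a functional assay on GTL 16 cells for antiproliferative activity against GTL 16 cell line (Homo sapiens), read by CCK-8 assay, with a stated time of 72 h; a higher number here means a weaker inhibitor, a lower number a stronger inhibitor. It stands highest of the three numbers in hand. Compound 1 `O=C(Nc1cccc(-c2oc3cc(-c4ccc(F)cc4)ccc3c(=O)c2O)c1)c1ccc(Cl)cc1` gives 9140 nM and compound 3 `O=C(Nc1cccc(-c2oc3cc(-c4ccc(F)cc4)ccc3c(=O)c2O)c1)c1cccc(F)c1` gives 15800 nM. The step of a 2.8-fold higher number from compound 1 to compound 2 (0.44 log units; beyond the scatter) is the only one of the three that reaches beyond the scatter; the step of a 1.6-fold lower number from compound 2 to compound 3 (0.21 log units; within the scatter) does not, nor does a 1.7-fold higher number from compound 1 to compound 3 (0.24 log units; within the scatter).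

Compound 4 `O=C(Nc1cccc(-c2oc3cc(-c4ccc(F)cc4)ccc3c(=O)c2O)c1)c1ccc([N+](=O)[O-])cc1` is the next compound and differs from compound 2 as follows: nitro in place of bromo on an aromatic carbon. Among the compounds with values here, no measured step in this set swaps a halogen for a nitro group, so the bearing of the measured steps is indirect: the halogen swap from compound 1 to compound 2 moved the number modestly, and the change from compound 2 to compound 3 stayed within the scatter. Within the data shown here, the whole series so far spans less than a factor that would mark a clear trend, so for compound 4 a step of a 1.4-fold lower number from compound 2 to compound 4 (0.15 log units; within the scatter) is expected, meaning roughly no change beyond the scatter. The estimate for compound 4 is therefore 18000 nM, with a range from 6000 nM to 55000 nM.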

Compound 4, half-maximal inhibitory concentration: 18200 nM
Compound 4: middle estimate off by 1.0-fold (0.00 log units), on the low side, within the range that was stated.
By their numbers in this assay, from the lowest: compounds 1, 3, 4 and 2 (each within the scatter of the next, the first and the last beyond it).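

In this assay, the position on the aromatic carbon para to a large group accepts nitro, which brings hydrogen-bond acceptors that the halogens lack, with no step beyond the scatter from either halogen (for bromo, a 1.4-fold lower number from compound 2 to compound 4 (0.14 log units; within the scatter); for chloro, a 2.0-fold higher number from compound 1 to compound 4 (0.30 log units; within the scatter)). The 4-nitrophenyl amide also stays within the scatter of the 3-fluorophenyl amide (a 1.2-fold higher number from compound 3 to compound 4 (0.06 log units; within the scatter)), so compound 4 does not separate from any of the three earlier compounds, and a non-halogen group at this place gives no new level of activity. Nothing at hand explains this tolerance of nitro.

As far as these compounds go, whether an amine, a carboxylic acid or a methoxy group at this place would stay in the same range remains open. Also open, from the compounds shown here alone, is whether a change elsewhere on the shared core would move the number further than these benzamide substituents do.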